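Secondary Amine Linker Variation in Bis(trifluoromethyl)benzenesulfonamides

The compounds below may be only part of what the source reports. "The series", "measured", "known", "first", "only" and "open" are said of these compounds alone.

Measured so far:
compound 1, `O=S(=O)(NCCNCc1cccc2ccccc12)c1cc(C(F)(F)F)cc(C(F)(F)F)c1`, 21000 nM
compound 2, `CN(CCCNS(=O)(=O)c1cc(C(F)(F)F)cc(C(F)(F)F)c1)Cc1ccccc1`, 46000 nM

The two compounds were compared in a functional assay on Capan-2 cells (Homo sapiens) for inhibition, read by MTT assay, with a stated time of 72 h; on this read-out higher numbers stand for weaker inhibition of growth and lower numbers for stronger inhibition of growth. Compound 1 gives 21000 nM, while compound 2 gives 46000 nM, the higher of the two numbers and beyond the usual scatter from compound 1, so compound 2 is the weaker inhibitor of growth in this assay.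

Compound 3, `O=S(=O)(NCCCNCc1ccc(Cl)cc1)c1cc(C(F)(F)F)cc(C(F)(F)F)c1`, has not been measured. It differs from compound 2 in one place: (4-chlorobenzyl)amino in place of benzyl(methyl)amino on a saturated chain carbon, three bonds along the chain from a sulfonamide nitrogen. With this change compound 3 carries a secondary amine in the chain, as compound 1 does, and compound 1 gives 21000 nM in this assay. Going by the values given here, no measured step isolates this change, so the expectation rests on that resemblance alone. The step of a 1.8-fold lower number from compound 2 to compound 3 (0.26 log units; within the scatter) is expected to be modest, toward stronger inhibition. Compound 3 is therefore estimated at 25000 nM, within a range from 8000 nM to 70000 nM.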

Compound 3, concentration for 50% growth inhibition: 2700 nM
The estimate for compound 3 lay 9.3-fold (0.97 log units) above the measured number, outside the stated range (below it).
By their numbers in this assay, from the lowest: compound 3; then compound 1; then compound 2.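

In this assay, putting (4-chlorobenzyl)amino in place of benzyl(methyl)amino on a saturated chain carbon, three bonds along the chain from a sulfonamide nitrogen, gives a 17-fold lower number from compound 2 to compound 3 (1.23 log units; beyond the scatter) toward stronger inhibition of growth. Going by these compounds alone, this is the first single-place step, and it shows that inhibition responds strongly to the group at this position. The step joins two differences, since the entering group carries a chlorine and a hydrogen-bond donor that the leaving group lacks. No measurement shown here explains its size.

Which of the two differences carries the step stays open. Plain benzylamino or (4-chlorobenzyl)(methyl)amino at this position would separate them, and a 4-fluorobenzyl or 4-methoxybenzyl group would test whether chlorine itself matters.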